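This account rests on a few compounds, and the source may have more. Where it says the series, first, only, none or still open, it means among the compounds named here.

Working notes on the series. Among the measured compounds shown here, compound 3 `CC(C)(C)c1cc(NC(=O)[C@@H]2CCCCN2C(=O)CC2CCOCC2)no1` gives 1.83 h in an ADME assay (liver) for metabolic stability, with Liver microsome (Homo sapiens) as the target, read by LC-MS, using microsomes and NADPH, tested at 1 uM (on this read-out higher numbers stand for a longer-lived compound and lower numbers for a shorter-lived compound), the highest of the three numbers so far, although compound 2 `CC(C)(C)c1cc(NC(=O)[C@@H]2CCCCN2C(=O)c2ccc(Cl)cc2)no1` gives 1.25 h and the step of a 1.5-fold higher number from compound 2 to compound 3 (0.17 log units; within the scatter) lies within the scatter. Compound 1 `CC(C)(C)c1cc(NC(=O)[C@@H]2CCCCN2C2CCOCC2)no1` gives 0.317 h; the steps of a 3.9-fold higher number from compound 1 to compound 2 (0.60 log units; beyond the scatter) and a 5.8-fold higher number from compound 1 to compound 3 (0.76 log units; beyond the scatter) both go beyond the scatter. Compound 4 `CC(C)(C)c1cc(NC(=O)[C@@H]2CCCCN2C(=O)N2CCSCC2)no1` differs from compound 3 by thiomorpholin-4-yl in place of (oxan-4-yl)methyl on a carbonyl carbon. For the measured compounds named here, the only measured step of the same kind, an exchange of the group on the carbonyl carbon while the carbonyl itself stays, is the one from compound 2 to compound 3, and it stayed within the scatter. The step of a 1.2-fold lower number from compound 3 to compound 4 (0.09 log units; within the scatter) is therefore expected to be within the scatter. Compound 4 is estimated at 1.5 h, range 0.6 h to 3.5 h.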

Compound 4, half-life: < 0.0834 h
Compound 4: only a limit was reported; the forecaster's own chance of this, stated with the estimate: 5%; middle value at least 17-fold (1.25 log units) from the limit.
By their numbers in this assay, from the lowest: compound 1; then compounds 2 and 3 (each within the scatter of the next). At a limit, below all of these: compound 4.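

On the carbonyl carbon the group now matters: an at least 21-fold lower number from compound 3 to compound 4 (1.34 log units; beyond the scatter) and an at least 14-fold lower number from compound 2 to compound 4 (1.17 log units; beyond the scatter) are both large, whereas a 1.5-fold higher number from compound 2 to compound 3 (0.17 log units; within the scatter) showed no such sensitivity. The carbonyl alone does not secure a longer half-life, as an at least 3.8-fold lower number from compound 1 to compound 4 (0.57 log units; beyond the scatter) leads to a compound that keeps the carbonyl yet falls under the one with oxan-4-yl on the amine nitrogen in a ring. Compound 4 stands at a limit, not a number: the limit of < 0.0834 h in this assay, at which 1 of the 4 values shown sits.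

Open, from the compounds shown here alone, is whether the loss goes with the sulfur or with the ring nitrogen on the carbonyl carbon. A morpholin-4-yl group, with oxygen in place of sulfur, would separate the two.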